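Swapping Fluoro for Tert-Butyl on a Shared Core

This account rests on a few compounds, and the source may have more. Where it says the series, first, only, none or still open, it means among the compounds named here.

Compound 1 `NC1=NC2(CCOCC2)N(OCCCOc2ccc(F)cc2)C(N)=N1` was tested in an assay on isolated protein for inhibition of Dihydrofolate reductase (Homo sapiens), read by spectrophotometry, using NADPH, with stated times of 5 s and 6 min (a higher number here means a weaker inhibitor, a lower number a stronger inhibitor), where compound 1 gives 46.6 nM. Among the numbers obtained this is the highest; the nearest is compound 2 `NC1=NC2(CCOCC2)N(OCCCOc2cc(Cl)c(Cl)cc2Cl)C(N)=N1`, which in this assay gives 36 nM, a step of a 1.3-fold lower number from compound 1 to compound 2 (0.11 log units; within the scatter). Compound 3 `NC1=NC2(CCOCC2)N(OCCCOc2ccccc2Cl)C(N)=N1` has in this assay "not determined" (no result reported). The new compound 4 `CC(C)(C)c1ccc(OCCCON2C(N)=NC(N)=NC23CCOCC3)cc1` differs from compound 1 in one place: tert-butyl in place of fluoro on an aromatic carbon. Among the measured compounds shown here, the only measured step, from compound 1 to compound 2, also alters groups on the six-membered aromatic ring of carbon only and stays within the scatter, yet no measured pair exchanges fluoro for tert-butyl. The expectation is therefore a step of a 1.0-fold lower number from compound 1 to compound 4 (0.02 log units; within the scatter) in this assay, nothing beyond the scatter. Compound 4 is estimated at 45 nM, within 18 nM to 110 nM.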

Compound 4, half-maximal inhibitory concentration: 3.72 nM
Compound 4: the middle estimate sits 12-fold (1.08 log units) above what was measured; measured number outside the range, below it.
By their numbers in this assay, from the lowest: compound 4; then compounds 2 and 1 (each within the scatter of the next).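

The exchange of fluoro for tert-butyl gives a 13-fold lower number from compound 1 to compound 4 (1.10 log units; beyond the scatter) in this assay and so shows that a change at this aromatic carbon can move the number beyond the scatter, which the earlier step did not. The four carbon atoms that enter bring no ring, hydrogen-bond donor or acceptor, and neither did the fluoro that leaves. No measurement shown here explains this drop. Open, on these data alone, is whether a methyl, an isopropyl or a trifluoromethyl at this carbon would give a similar number, and whether tert-butyl would keep its effect on a longer chain.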